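A few compounds are considered here, and "the series" means these few. Any claim that something is new, unique, unknown or untested is made for them only; others in the source may bear on it.

Working notes on the series. Of the compounds shown here, two have numbers so far. Compound 1 `O=C(Nc1cccc(-n2cc(-c3ccncc3)c(-c3ccc(Cl)c(O)c3)n2)c1)Nc1cccc(C(F)(F)F)c1` gives 14500 nM in a functional assay on NCI-H522 cells (Homo sapiens) for inhibition, read by sulforhodamine B assay, with a stated time of 48 h; on this read-out higher numbers stand for weaker inhibition of growth and lower numbers for stronger inhibition of growth. Compound 2 `COc1cc(-c2nn(-c3cccc(NC(=O)Nc4cc(C(F)(F)F)cc(C(F)(F)F)c4)c3)cc2-c2ccncc2)ccc1Cl` gives 1800 nM in the same assay; this is the lower of the two numbers, and the gap to compound 1 is beyond the scatter. The two differ in more than one place, so neither change can be isolated from these values alone.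

Compound 3 `O=C(Nc1cccc(-n2cc(-c3ccncc3)c(-c3ccc(Cl)c(O)c3)n2)c1)Nc1cc(C(F)(F)F)cc(C(F)(F)F)c1` is not yet measured. It departs from compound 2 by hydrogen in place of methyl on an oxygen on an aromatic ring, that is, 4-chloro-3-methoxyphenyl becomes 4-chloro-3-hydroxyphenyl, while the bis(trifluoromethyl)phenyl urea of compound 2 is kept. Going by the values given here, compound 1 carries the same hydroxy group but a different urea, so no measured pair shows this step by itself. The expectation is a modest move toward a higher number, a 1.7-fold higher number from compound 2 to compound 3 (0.22 log units; within the scatter), not clearly beyond the scatter. For compound 3 the estimate is 3000 nM, with a range from 1200 nM to 9000 nM.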

Compound 3, concentration for total growth inhibition: 2510 nM
For compound 3 the middle estimate is 1.2-fold (0.08 log units) above the measured one; measured number inside the range.
By their numbers in this assay, from the lowest: compounds 2 and 3 (each within the scatter of the next); then compound 1.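

In this assay, the change from methoxy to hydroxy on the oxygen of the 4-chloro-3-hydroxyphenyl group can now be read alone, with the bis(trifluoromethyl)phenyl urea held constant: a 1.4-fold higher number from compound 2 to compound 3 (0.14 log units; within the scatter), so this change does not separate the two compounds. The urea can also be read alone for the first time, with the hydroxy group held constant: trifluoromethyl in place of hydrogen on an aromatic carbon gives a 5.8-fold lower number from compound 1 to compound 3 (0.76 log units; beyond the scatter), so among these single changes only the one on the urea goes beyond the scatter. Nothing available bears on the cause of either step.

On these data alone, it remains open how an ethoxy group or a longer alkoxy chain on this oxygen would read, or an amine in place of the hydroxy group. As far as these compounds go, whether the methoxy to hydroxy step stays within the scatter on the urea of compound 1 also remains open.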